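This account rests on a few compounds, and the source may have more. Where it says the series, first, only, none or still open, it means among the compounds named here.

Measured in a functional assay on MDA-MB-231 cells (Homo sapiens) for antiproliferative activity, read by MTT assay, with a stated time of 48 h; a higher number here means a weaker inhibitor, a lower number a stronger inhibitor:

- Compound 1 `C=CS(=O)(=O)N1CCN(c2ccn3ncc(-c4ccccc4)c3n2)CC1`: 38300 nM
- Compound 2 `C=CS(=O)(=O)N1CCN(c2ncnc3sc(-c4cccc5ccccc45)cc23)CC1`: 23700 nM
- Compound 3 `C=CS(=O)(=O)N1CCN(c2ncnc3sc(-c4cn(S(=O)(=O)c5ccccc5)c5ccccc45)cc23)CC1`: 40400 nM

Compound 2 sits level with the other two, within the usual scatter of both. Compound 4 `C=CS(=O)(=O)N1CCN(c2ncnc3sc(-c4ccc(F)nc4)cc23)CC1` carries 6-fluoropyridin-3-yl in place of naphthalen-1-yl on an aromatic carbon of compound 2: 6-fluoropyridin-3-yl in place of naphthalen-1-yl on an aromatic carbon. Going by the values given here, no measured pair differs in one place only, so the size of this step in this assay can only be expected, not read off. With another group on that carbon and the same core as compound 2, compound 3 gives 40400 nM, so no step beyond the scatter is expected, in either direction. The expected move, a 1.3-fold higher number from compound 2 to compound 4 (0.10 log units; within the scatter), is small. For compound 4 the estimated value is 30000 nM, with an expected range of 12000 nM to 70000 nM.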

Compound 4, half-maximal inhibitory concentration: 16000 nM
Compound 4: middle estimate off by 1.9-fold (0.27 log units), on the high side, within the range that was stated.
By their numbers in this assay, from the lowest: compounds 4, 2, 1 and 3 (each within the scatter of the next, the first and the last beyond it).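

In this assay, going by these compounds alone, the first step that changes only one place puts 6-fluoropyridin-3-yl in place of naphthalen-1-yl on the aromatic carbon next to the ring sulfur, and a 1.5-fold lower number from compound 2 to compound 4 (0.17 log units; within the scatter) stays within the scatter. At this position, one six-membered aromatic ring with a hetero atom can therefore replace two six-membered aromatic rings of carbon only without a change that can be told from the scatter.

From the compounds shown here alone, whether an amine or a carboxylic acid on that carbon would move the number beyond the scatter remains open. No measurement shown explains why this step is small.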